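A few compounds are considered here, and "the series" means these few. Any claim that something is new, unique, unknown or untested is made for them only; others in the source may bear on it.

Compound 2, `O=C(Nc1ccc(F)c(-c2nc3ncc(-c4cc(F)ccc4F)cc3[nH]2)c1)N1CCCC1`, is the starting point. In an ADME assay on HepG2 cells (Homo sapiens) for cytotoxicity, read by resazurin assay, with a stated time of 48 h (on this read-out lower numbers stand for an effect already at smaller amounts and higher numbers for an effect only at larger amounts of compound), compound 2 gives > 50000 nM, which is a limit of the assay rather than a number. Two close relatives have been run in the same test. Compound 1, `O=C(Nc1ccc(F)c(-c2nc3ncc(-c4ccc(F)c(F)c4)cc3[nH]2)c1)N1CCCC1`, carries a 3,4-difluorophenyl on the shared core; in this assay compound 1 gives > 50000 nM, again a limit. Compound 3, `O=C(Nc1ccc(F)c(-c2nc3ncc(-c4ccc(F)cc4)cc3[nH]2)c1)N1CCCC1`, carries a 4-fluorophenyl; in this assay compound 3 gives > 50000 nM, also a limit. Because every value sits at the limit of > 50000 nM in this assay, at which 3 of the 3 values shown sit, none of the steps can be read: a step that the two limits leave unreadable from compound 1 to compound 2, a step that the two limits leave unreadable from compound 1 to compound 3 and a step that the two limits leave unreadable from compound 2 to compound 3 are all hidden by the limits.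

The new compound 4, `O=C(Nc1ccc(F)c(-c2nc3ncc(-c4cccc(F)c4F)cc3[nH]2)c1)N1CCCC1`, differs from compound 2 in one place: 2,3-difluorophenyl in place of 2,5-difluorophenyl on an aromatic carbon. The three measured steps are the ones that bear on this change, and each of them shows only that swapping fluorines around this phenyl ring left the read-out at the limit. For the measured compounds named here, no step in this assay beyond the scatter is therefore expected; the estimated step of a number no higher from compound 2 to compound 4 (the limit leaves the size open) is flat. Compound 4 is estimated to give 50000 nM in this assay, within 20000 nM to 150000 nM, most likely again reported as a limit.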

Compound 4, half-maximal effective concentration: > 50000 nM
Compound 4: only a limit was reported (the forecaster's own chance of this, stated with the estimate: 85%); the middle value sits exactly at the limit.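

In this assay compound 4 gives > 50000 nM, again a limit of the assay, and its steps from compound 1, compound 2 and compound 3 cannot be read. The four compounds share one ceiling: the limit of > 50000 nM in this assay, at which 4 of the 4 values shown sit. The compounds shown leave open how far they truly differ, and whether any phenyl substitution would give a measurable effect.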